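Boron-containing amides on WI-38 cells: from methylsulfanyl to cyano

The compounds below may be only part of what the source reports. "The series", "measured", "known", "first", "only" and "open" are said of these compounds alone.

Measured compounds:
Compound 1, `O=C(CCc1cccc2c1B(O)OC2)Nc1cccc(-c2ccc(Cl)cc2)c1`: 9800 nM
Compound 2, `CSc1cccc(-c2cccc(NC(=O)CCc3cccc4c3B(O)OC4)c2)c1`: 2000 nM

In an ADME assay on WI-38 cells (Homo sapiens) for cytotoxicity, read by MTT assay, with a stated time of 72 h (on this read-out lower numbers stand for stronger inhibition and higher numbers for weaker inhibition), compound 2 gives the lower of the two numbers, and compound 1 stands apart from it by a 4.9-fold lower number from compound 1 to compound 2 (0.69 log units; beyond the scatter). Compound 3, `N#Cc1ccc(-c2cccc(NC(=O)CCc3cccc4c3B(O)OC4)c2)cc1`, differs from compound 2 by 4-cyanophenyl in place of 3-(methylsulfanyl)phenyl on an aromatic carbon. Among the compounds with values here, the only step that bears on this change is the one from compound 1 to compound 2, which also swapped the aromatic group at the same carbon and moved the number beyond the scatter. A step of similar size in either direction is therefore plausible, and the middle estimate is set near compound 2 with a wide range: compound 3 is expected at 4000 nM (range 1500 nM to 12000 nM), a step of a 2.0-fold higher number from compound 2 to compound 3 (0.30 log units; within the scatter).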

Compound 3, half-maximal inhibitory concentration: 12000 nM
Estimate against measurement, compound 3: 3.0-fold (0.48 log units) below, and the stated range covers the measured number.
By their numbers in this assay, from the lowest: compound 2; then compounds 1 and 3 (each within the scatter of the next).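

In this assay, 4-cyanophenyl in place of 3-(methylsulfanyl)phenyl gives a 6.0-fold higher number from compound 2 to compound 3 (0.78 log units; beyond the scatter), so the number at this aromatic carbon moves up as well as down with the group placed there. Cyano in place of chloro gives a 1.2-fold higher number from compound 1 to compound 3 (0.09 log units; within the scatter), so among these three only compound 2 stands apart. Nothing shown gives a reason for these steps.

As far as these compounds go, whether the step follows the methylsulfanyl group itself or the place it holds on the phenyl ring stays open. So does the effect of an amine or a carboxylic acid on that ring.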